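Amide Variation on a Shared Core in a Cytotoxicity Assay

The source may report more compounds than this note shows. Statements on the series, on what has been measured and on what is new or still open speak of the compounds shown alone.

compound 1 `CNC(=O)Cn1nc(N)c2c(C(F)(F)F)cc(-c3ccccc3)nc21` — 15300 nM
compound 2 `NCCNC(=O)Cn1nc(N)c2c(C(F)(F)F)cc(-c3ccccc3)nc21` — 50200 nM
compound 3 `Nc1nn(CC(=O)NCc2ccco2)c2nc(-c3ccccc3)cc(C(F)(F)F)c12` — 7700 nM

Three compounds on a shared core were tested in a functional assay on A549 cells (Homo sapiens) for cytotoxicity, read by MTT assay, with a stated time of 24 h; on this read-out lower numbers stand for stronger inhibition and higher numbers for weaker inhibition. Compound 2 stands highest of the three numbers, its nearest neighbour being compound 1 and its furthest compound 3. Compound 4 `Nc1nn(CC(=O)N2CCOCC2)c2nc(-c3ccccc3)cc(C(F)(F)F)c12` is not yet measured; it differs from compound 2 by morpholin-4-yl in place of (2-aminoethyl)amino on a carbonyl carbon. Going by the values given here, two measured steps bear on this change, since both remove the amine-bearing chain from the amide: a 3.3-fold higher number from compound 1 to compound 2 (0.52 log units; beyond the scatter) read in reverse, and a 6.5-fold lower number from compound 2 to compound 3 (0.81 log units; beyond the scatter). Both point toward a lower number once the (2-aminoethyl)amino group is gone, though neither introduces a ring onto the carbonyl nitrogen, so the size is uncertain. Compound 4 is therefore expected to move a 3.9-fold lower number from compound 2 to compound 4 (0.59 log units; beyond the scatter), landing near compound 1. The estimate for compound 4 is 13000 nM, with a range from 4000 nM to 40000 nM.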

Compound 4, half-maximal inhibitory concentration: 5400 nM
For compound 4 the middle estimate is 2.4-fold (0.38 log units) above the measured one, within the range that was stated.
By their numbers in this assay, from the lowest: compounds 4, 3 and 1 (each within the scatter of the next, the first and the last beyond it); then compound 2.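

In this assay, going by these compounds alone, morpholin-4-yl on the carbonyl carbon removes the amide hydrogen present in all the earlier compounds, and the number still falls, with a 9.3-fold lower number from compound 2 to compound 4 (0.97 log units; beyond the scatter) and a 2.8-fold lower number from compound 1 to compound 4 (0.45 log units; beyond the scatter) as the steps. Against the furan-bearing amide, a 1.4-fold lower number from compound 3 to compound 4 (0.15 log units; within the scatter) separates the two no more than the usual scatter, so the ring and the ((furan-2-yl)methyl)amino group read alike here. No measurement shown accounts for these steps. The compounds shown leave open whether the morpholine oxygen matters, which a piperidin-1-yl group would test, and whether a longer chain ending in an amine would raise the number further.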